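Rearranging the side-chain hydroxyl: compound 2 to compound 3

The source may hold more compounds than are shown below. What is called first, only, known or untested is meant among the compounds shown, and "the series" means these compounds.

Compound 1, `CC(C)=CCC/C(C)=C/Cc1c(O)cc2c(c1O)C(=O)C[C@@H](c1ccc(O)c(O)c1)O2`: < 10000 nM
Compound 2, `C=C(C)C(O)CC/C(C)=C/Cc1c(O)cc2c(c1O)C(=O)C[C@@H](c1ccc(O)c(OC)c1)O2`: > 10000 nM

Within the data shown here, only two compounds have been measured, and neither gives a true number. In a functional assay on HeLa cells (Homo sapiens) for cytotoxicity, with a stated time of 72 h (a lower number here means that less compound is needed, a higher number that more compound is needed for the effect), compound 1 gives < 10000 nM, which is a limit of the assay rather than a measured value (the limit of < 10000 nM in this assay, at which 1 of the 2 values shown sits). Compound 2 in this assay gives > 10000 nM, again a limit and not a number (the limit of > 10000 nM in this assay, at which 1 of the 2 values shown sits). Among the measured compounds shown here, compound 2 therefore stands at the upper limit of what this assay reports, and the one other value shown is itself a limit, so no measured step is available to compare it against.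

Compound 3, `COc1cc([C@@H]2CC(=O)c3c(cc(O)c(C/C=C(\C)C/C=C/C(C)(C)O)c3O)O2)ccc1O`, is still to be measured in this assay. It differs from compound 2 by 3-hydroxy-3-methylbut-1-en-1-yl in place of 2-hydroxy-3-methylbut-3-en-1-yl on a saturated chain carbon bound to a double-bonded chain carbon. For the measured compounds named here, the two have the same atoms joined differently, and no measured step connects them. The expected step is none beyond the usual scatter, which is taken as a step that the limit leaves unreadable from compound 2 to compound 3. Compound 3 is accordingly estimated at 15000 nM, with a range from 5000 nM to 50000 nM, and the assay is expected most likely to report only a limit again.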

Compound 3, half-maximal effective concentration: > 10000 nM
Compound 3 was reported as a limit; the forecaster's own chance of this, stated with the estimate: 70%; the middle value lies beyond the limit too.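

In this assay compound 3 gives > 10000 nM, which is a limit and not a number. Among these compounds, compound 2 also stands at a limit, so no step between compound 2 and compound 3 can be read. The compounds shown leave open whether 3-hydroxy-3-methylbut-1-en-1-yl in place of 2-hydroxy-3-methylbut-3-en-1-yl changes the true value in this assay at all.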